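Replacing the styryl arm: an expectation for compound 3

A few compounds are considered here, and "the series" means these few. Any claim that something is new, unique, unknown or untested is made for them only; others in the source may bear on it.

Compound 1 `Cc1cc(O)c(C2=NN(c3ccc(S(N)(=O)=O)cc3)C(c3ccccc3O)C2)cc1Cl`: 2470 nM
Compound 2 `Cc1cc(O)c(C2=NN(c3ccc(S(N)(=O)=O)cc3)C(/C=C/c3ccccc3)C2)cc1Cl`: 6120 nM

In a functional assay on BT-549 cells (Homo sapiens) for antiproliferative activity, with a stated time of 48 h (a higher number here means a weaker inhibitor of growth, a lower number a stronger inhibitor of growth), compound 1 gives 2470 nM and compound 2 gives 6120 nM; compound 2 thus holds the higher of the two numbers. Among the measured compounds shown here, the single measured step is a 2.5-fold higher number from compound 1 to compound 2 (0.39 log units; beyond the scatter), where 2-phenylethenyl replaced an aryl group. Compound 3 `COc1ccc(C2CC(c3cc(Cl)c(C)cc3O)=NN2c2ccc(S(N)(=O)=O)cc2)c(OC)c1OC` differs from compound 2 by 2,3,4-trimethoxyphenyl in place of 2-phenylethenyl on a saturated ring carbon. For the measured compounds named here, since that one step raised the number modestly when an aryl group left, returning an aryl group is expected to lower it modestly, with wide uncertainty because the trimethoxy pattern has no precedent among the measured compounds. Compound 3 is estimated at 3000 nM, between 900 nM and 10000 nM. The expected step is a 2.0-fold lower number from compound 2 to compound 3 (0.31 log units; beyond the scatter).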

Compound 3, concentration for 50% growth inhibition: 2600 nM
Beside the measured number, compound 3's estimate is 1.2-fold (0.06 log units) above it, and the stated range covers the measured number.
By their numbers in this assay, from the lowest: compounds 1 and 3 (each within the scatter of the next); then compound 2.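

In this assay, 2,3,4-trimethoxyphenyl on the saturated ring carbon gives a 2.4-fold lower number from compound 2 to compound 3 (0.37 log units; beyond the scatter), so a second aryl group now stands apart from 2-phenylethenyl. Against 2-hydroxyphenyl, the same group gives a 1.1-fold higher number from compound 1 to compound 3 (0.02 log units; within the scatter), and these two aryl groups cannot be told apart at this position. No supporting measurement bears on these steps. Still open, going by these compounds, is whether a saturated 2-phenylethyl arm would behave like 2-phenylethenyl or like the aryl groups. Also open, on these data alone, is how a 4-aminophenyl group at this position would compare.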